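This account rests on a few compounds, and the source may have more. Where it says the series, first, only, none or still open, it means among the compounds named here.

Measured so far in an assay on CHO cells for displacement of a labelled ligand from adenosine receptor A1 (Homo sapiens), read by scintillation counting, with a stated time of 120 min, tested at 1 uM; a higher number here means more inhibition at the concentration tested (going by the name of the read-out), a lower number less inhibition:

compound 1, `CC(=O)Nc1nc(C)nc2cn(-c3ccccc3)nc12`: 25%
compound 2, `O=C(Nc1nc(-c2ccccc2)nc2cn(-c3ccccc3)nc12)c1ccncc1`: 1%
compound 3, `COc1ccc(C(=O)Nc2nc(C)nc3cn(-c4ccccc4)nc23)cc1`: 4%

For the measured compounds named here, compound 3 stands among the three numbers as follows: its inhibition lies within the scatter of compound 2, and the only step beyond the scatter that touches it is the drop a number 21 percentage points lower from compound 1 to compound 3 (beyond the scatter), a modest one, where 4-methoxyphenyl replaced methyl on the carbonyl carbon. Compound 4, `Cc1nc(NC(=O)c2ccncc2)c2nn(-c3ccccc3)cc2n1`, is not yet measured. It differs from compound 3 in one place: pyridin-4-yl in place of 4-methoxyphenyl on a carbonyl carbon. Going by the values given here, of the measured steps, only the one from compound 1 to compound 3 concerns the group on the carbonyl carbon, and it shows that an aryl in that place gave a lower number than methyl. Among the compounds with values here, no measured step exchanges 4-methoxyphenyl for pyridin-4-yl directly; compound 2, which also carries pyridin-4-yl on the carbonyl carbon but with phenyl elsewhere on the core, gives a number within the scatter of compound 3. Nothing therefore points to a move beyond the scatter in this assay in either direction. Compound 4 is expected to give 4%, with the range 0% to 12%. The step of no change at the digits printed from compound 3 to compound 4 (within the scatter) that this estimate means is expected to stay within the scatter.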

Compound 4, a percentage reported as inhibition, at one concentration (the size of the read-out at that concentration, not a potency): 12%
Estimate against measurement, compound 4: 8 percentage points below; low and high end bracket the measured number.
By their numbers in this assay, from the lowest: compounds 2, 3 and 4 (each within the scatter of the next, the first and the last beyond it); then compound 1.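

On the carbonyl carbon, the exchange of 4-methoxyphenyl for pyridin-4-yl in this assay leaves the two aryl groups unseparated (a number 8 percentage points higher from compound 3 to compound 4 (within the scatter)), so a ring nitrogen in place of the methoxy-bearing carbon ring makes no readable difference here on the shared core. A second aryl group now also goes with a lower number than methyl on the carbonyl carbon (a number 13 percentage points lower from compound 1 to compound 4 (beyond the scatter)), with no compound shown against this, while the aromatic carbon gets its first reading with pyridin-4-yl held constant, where methyl in place of phenyl gives a modest step (a number 11 percentage points higher from compound 2 to compound 4 (beyond the scatter)). For the compounds shown here, nothing measured so far accounts for any of these steps.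

From the compounds shown here alone, it remains open whether the lower number belongs to aryl groups as such or also appears with other groups on the carbonyl carbon, such as an ethyl group, a longer alkyl chain, a cyclohexyl ring or an amine. On the aromatic carbon only methyl and phenyl are shown, so the reading for an ethyl group, a methoxy group or an amine there is unknown.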